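The source may hold more compounds than are shown below. What is called first, only, known or untested is meant among the compounds shown, and "the series" means these compounds.

Measured compounds:
- compound 1 `CC(C)NC(=O)[C@H]1CC[C@@H](n2/c(=N/C(=O)c3ccc(F)cc3)[nH]c3ccc(CN4CCCCC4)cc32)CC1` gives 302 mL.min-1.g-1 in an in vitro ADME assay on microsomes from liver (Homo sapiens) for metabolic stability; on this read-out lower numbers stand for slow clearance and higher numbers for fast clearance
- compound 2 `CCOC(=O)[C@H]1CC[C@@H](n2/c(=N/C(=O)c3ccccc3)[nH]c3ccc(CN4CCCCC4)cc32)CC1` gives 222 mL.min-1.g-1 in this assay

Among the measured compounds shown here, only two numbers are known so far. Compound 2 stands at the lower of the two, with compound 1 the nearest; the gap between the values of compound 2 and compound 1 lies within the usual scatter of repeat measurements, so neither can be called the more stable of the pair. For the measured compounds named here, no step between measured compounds differing in one place has been measured.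

The next point in the series is compound 3 `CCN(CC)C(=O)[C@H]1CC[C@@H](n2/c(=N/C(=O)c3ccccc3)[nH]c3ccc(CN4CCCCC4)cc32)CC1`, which has not yet been measured. It differs from compound 2 in one place: diethylamino in place of ethoxy on a carbonyl carbon. The change sits on the carbonyl carbon whose other neighbour is a saturated ring carbon, and leaves the rest of the shared core untouched.

Nothing in the two measured values allows a step of this kind to be sized. The working expectation is that the step from compound 2 to compound 3 stays within the scatter, with no clear direction; the expected step is a 1.1-fold higher number from compound 2 to compound 3 (0.05 log units; within the scatter). Compound 3 is therefore estimated at 250 mL.min-1.g-1, with a range of 120 mL.min-1.g-1 to 500 mL.min-1.g-1.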

Compound 3, intrinsic clearance in microsomes: 364 mL.min-1.g-1
Compound 3: the middle estimate sits 1.5-fold (0.16 log units) below what was measured, within the range that was stated.
By their numbers in this assay, from the lowest: compounds 2, 1 and 3 (each within the scatter of the next).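

Among the compounds shown here, this is the first step read at the carbonyl carbon whose other neighbour is a saturated ring carbon: in this assay, diethylamino in place of ethoxy gives a 1.6-fold higher number from compound 2 to compound 3 (0.21 log units; within the scatter) and so does not separate the pair. On this one pair, ethoxycarbonyl and diethylcarbamoyl cannot be told apart on intrinsic clearance, even though the entering group is the larger by heavy-atom count and brings nitrogen in place of oxygen. No measurement is available that bears on this result or offers an explanation for it.

For the compounds shown here, compound 1 differs from compound 2 and from compound 3 in more than one place, so it adds no clean step at this position, and a single pair cannot show whether other groups on this carbonyl carbon would also stay within the scatter. On these data alone, a carboxylic acid, a primary amide or a cyclic amine such as morpholine at the same place remains open, as does whether any such exchange would move the clearance by more than the scatter.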